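A few compounds are considered here, and "the series" means these few. Any claim that something is new, unique, unknown or untested is made for them only; others in the source may bear on it.

Two compounds share one core and differ only in the aromatic group attached to it. Compound 1 `c1ccc2c(-c3cn4ccnc4c(-c4ccc5ncn(C6CCCCC6)c5c4)n3)cccc2c1` carries a naphthalen-1-yl group there, and in a functional assay on MCF7 cells (Homo sapiens) for inhibition, read by sulforhodamine B assay, with a stated time of 48 h, tested at 10 uM (a lower number here means less inhibition, a higher number more inhibition at the concentration tested (going by the name of the read-out)), compound 1 gives 13%. Compound 2 `COc1ccccc1-c1cn2ccnc2c(-c2ccc3ncn(C4CCCCC4)c3c2)n1` carries a 2-methoxyphenyl group in its place, and in this assay compound 2 gives 8.4%. That exchange produced a number 4.6 percentage points lower from compound 1 to compound 2 (within the scatter), so compound 2 holds the lowest of the two numbers shown, with compound 1 as its only neighbour at a distance within the scatter. Compound 3 `FC(F)(F)c1cccc(-c2cn3ccnc3c(-c3ccc4ncn(C5CCCCC5)c4c3)n2)c1` alters the same position once more: 3-(trifluoromethyl)phenyl in place of 2-methoxyphenyl on an aromatic carbon. Going by the values given here, the single measured step, from compound 1 to compound 2, is the only one that bears on this kind of swap, and it stayed within the scatter. No movement beyond the scatter is therefore expected for compound 3 in this assay, which amounts to an expected a number 1.6 percentage points higher from compound 2 to compound 3 (within the scatter). Compound 3 is accordingly estimated at 10%, with a range from 0% to 25%.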

Compound 3, a percentage reported as inhibition, at one concentration (the size of the read-out at that concentration, not a potency): 19.9%
Compound 3: middle estimate off by 9.9 percentage points, on the low side, within the range that was stated.
By their numbers in this assay, from the lowest: compounds 2, 1 and 3 (each within the scatter of the next, the first and the last beyond it).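

In this assay, this position now shows a response to the group it carries: a number 11.5 percentage points higher from compound 2 to compound 3 (beyond the scatter), a modest step and the first here to pass beyond the scatter. Set against the naphthalen-1-yl group, the same 3-(trifluoromethyl)phenyl group gives a number 6.9 percentage points higher from compound 1 to compound 3 (within the scatter), so among these steps only the exchange of 2-methoxyphenyl for 3-(trifluoromethyl)phenyl separates two compounds clearly. No measurement shown explains this difference.

The exchange alters two things at once, the substituent on the phenyl ring and its place, so the compounds shown cannot separate the contribution of either. On these data alone, it also remains open how the number would respond to a phenyl ring carrying an amine or a carboxylic acid at this position.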